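A few compounds are considered here, and "the series" means these few. Any claim that something is new, unique, unknown or untested is made for them only; others in the source may bear on it.

Three compounds share one core and differ only in the aryl group on an amine nitrogen in a ring: compound 1 `Nc1scc(CN2CCN(c3ccccc3C(F)(F)F)CC2)c1C(=O)c1ccc(Cl)cc1`, compound 2 `Nc1scc(CN2CCN(c3cccc4ccccc34)CC2)c1C(=O)c1ccc(Cl)cc1` and compound 3 `Nc1scc(CN2CCN(c3cc(F)cc(F)c3)CC2)c1C(=O)c1ccc(Cl)cc1`. In an assay on CHO cells for displacement of a labelled ligand from adenosine receptor A1 (Homo sapiens), read by scintillation counting, with a stated time of 120 min, tested at 10 uM (a lower number here means less inhibition, a higher number more inhibition at the concentration tested (going by the name of the read-out)), compound 1 gives 0%, compound 2 gives 1% and compound 3 gives 0%, so compound 3 sits level with compound 1 and all three numbers lie within the scatter of one another. The steps of no change at the digits printed from compound 1 to compound 3 (within the scatter) and a number 1 percentage points lower from compound 2 to compound 3 (within the scatter) show that changing this aryl group has so far left the read-out flat. Compound 4 `Nc1scc(CN2CCN(c3c(F)cc(F)cc3F)CC2)c1C(=O)c1ccc(Cl)cc1` differs from compound 3 by 2,4,6-trifluorophenyl in place of 3,5-difluorophenyl on an amine nitrogen in a ring. Because no change at the digits printed from compound 1 to compound 3 (within the scatter) and a number 1 percentage points lower from compound 2 to compound 3 (within the scatter) were both within the scatter, compound 4 is expected to remain flat, with an estimated step of no change at the digits printed from compound 3 to compound 4 (within the scatter). Compound 4 is therefore estimated at 0%, expected between -5% and 8%.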

Compound 4, a percentage reported as inhibition, at one concentration (the size of the read-out at that concentration, not a potency): 0%
Compound 4: middle estimate and measured number agree at the digits printed, and the stated range covers the measured number.
By their numbers in this assay, from the lowest: compounds 1, 3, 4 and 2 (each within the scatter of the next).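

In this assay, 2,4,6-trifluorophenyl in place of 3,5-difluorophenyl gives no change at the digits printed from compound 3 to compound 4 (within the scatter), so a third fluorine on this aryl ring leaves the read-out flat. Set against the two larger aryl groups, the same ring gives a number 1 percentage points lower from compound 2 to compound 4 (within the scatter) and no change at the digits printed from compound 1 to compound 4 (within the scatter), making this a fourth aryl group on the amine nitrogen with no measurable separation from the others. No supporting data bear on this result. On these data alone, all four compounds carry an aryl ring at this position, so it remains open whether a carboxylic acid on a longer chain here would give a different number.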